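This account rests on a few compounds, and the source may have more. Where it says the series, first, only, none or still open, it means among the compounds named here.

Two compounds have been measured so far in a functional assay on CCRF-CEM cells (Homo sapiens) for inhibition; a lower number here means a stronger inhibitor of growth, a higher number a weaker inhibitor of growth:

- compound 1 `C=C1C(=O)O[C@H]2[C@H]1CC/C(COC(=O)N1CCC(F)(F)CC1)=C\CC[C@@]1(C)O[C@@H]21` gives 680 nM
- compound 2 `C=C1C(=O)O[C@H]2[C@H]1CC/C(COC(=O)NCCN1CCCC1)=C\CC[C@@]1(C)O[C@@H]21` gives 2490 nM

Compound 2 stands at 2490 nM and has the higher of the two numbers, which makes it the weaker growth inhibitor of this pair. Compound 3 `C=C1C(=O)O[C@H]2[C@H]1CC/C(COC(=O)Nc1n[nH]c(SC)n1)=C\CC[C@@]1(C)O[C@@H]21` keeps the shared core and changes one group: 5-(methylsulfanyl)-1H-1,2,4-triazol-3-yl in place of 2-(pyrrolidin-1-yl)ethyl on an amide-type nitrogen. In words, 5-(methylsulfanyl)-1H-1,2,4-triazol-3-yl sits in place of 2-(pyrrolidin-1-yl)ethyl on an amide-type nitrogen.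

Within the data shown here, the only measured step that bears on this is a 3.7-fold higher number from compound 1 to compound 2 (0.56 log units; beyond the scatter) and it is modest. That step brought in the group that compound 3 now loses, so a downward step of similar size is expected. Among the measured compounds shown here, no measured compound carries the new group, which leaves this expectation loose. The estimated change is a 2.8-fold lower number from compound 2 to compound 3 (0.44 log units; beyond the scatter) in this assay for now. Compound 3 is expected at 900 nM (range 300 nM to 2700 nM).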

Compound 3, concentration for 50% growth inhibition: 620 nM
Estimate against measurement, compound 3: 1.5-fold (0.16 log units) above; the range from low to high includes it.
By their numbers in this assay, from the lowest: compounds 3 and 1 (each within the scatter of the next); then compound 2.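

Placing 5-(methylsulfanyl)-1H-1,2,4-triazol-3-yl on the amide-type nitrogen in place of 2-(pyrrolidin-1-yl)ethyl gives a 4.0-fold lower number from compound 2 to compound 3 (0.60 log units; beyond the scatter) in this assay, even though both groups have the same count of heavy atoms, so the identity of the group matters here and not only its size. The step with a 1.1-fold lower number from compound 1 to compound 3 (0.04 log units; within the scatter) links two very different groups, (5-(methylsulfanyl)-1H-1,2,4-triazol-3-yl)amino and 4,4-difluoropiperidin-1-yl on a carbonyl carbon, which leaves compound 2 as the one that stands apart. Nothing available explains why the numbers fall this way.

As far as these compounds go, it remains open whether the aromatic ring, the methylsulfanyl group or simply the absence of the pyrrolidine accounts for the step from compound 2. A plain 1H-1,2,4-triazol-3-yl without the sulfur group, or a phenyl ring on the same nitrogen, would help to separate these possibilities.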